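Amide substituent change on the hydroxy series

A few compounds are considered here, and "the series" means these few. Any claim that something is new, unique, unknown or untested is made for them only; others in the source may bear on it.

Measured so far in an assay on HL-60 cells for agonist activity at vitamin D3 receptor (Homo sapiens), read by microscopy, with a stated time of 96 h; on this read-out lower numbers stand for an effect already at smaller amounts and higher numbers for an effect only at larger amounts of compound:
compound 1 `C#CCNC(=O)c1ccc(C(CC)(CC)c2ccc(OCC(=O)C(C)(C)C)c(C)c2)n1CC` gives 2200 nM
compound 2 `CCn1c(C(=O)N(C)c2ccccc2)ccc1C(CC)(CC)c1ccc(OCC(=O)C(C)(C)C)c(C)c1` gives 18500 nM
compound 3 `C#CCNC(=O)c1ccc(C(CC)(CC)c2ccc(OCC(O)C(C)(C)C)c(C)c2)n1CC` gives 240 nM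

Compound 3 stands lowest of the three numbers. Its nearest neighbour is compound 1, as a 9.2-fold lower number from compound 1 to compound 3 (0.96 log units; beyond the scatter) shows; compound 2 lies furthest off. The two measured steps point in opposite directions: a 9.2-fold lower number from compound 1 to compound 3 (0.96 log units; beyond the scatter) on the chain carbon bound to the aromatic oxygen, and an 8.4-fold higher number from compound 1 to compound 2 (0.92 log units; beyond the scatter) on the carbonyl carbon.

Compound 4 `CCn1c(C(=O)N(C)CC(=O)O)ccc1C(CC)(CC)c1ccc(OCC(O)C(C)(C)C)c(C)c1` keeps the 1-hydroxy-2,2-dimethylpropyl group of compound 3 and alters the amide side only: (carboxymethyl)(methyl)amino in place of propargylamino on a carbonyl carbon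

Within the data shown here, the step that bears on this is an 8.4-fold higher number from compound 1 to compound 2 (0.92 log units; beyond the scatter), the only measured change at the carbonyl carbon. There the departure from propargylamino to a methyl-bearing tertiary amide raised the number modestly, beyond the scatter. Compound 4 also carries a methyl on that nitrogen, though the second group is now carboxymethyl rather than phenyl, for which no measured comparison exists. As far as these compounds go, a rise of roughly the same order as an 8.4-fold higher number from compound 1 to compound 2 (0.92 log units; beyond the scatter) is therefore expected for compound 4, with wide uncertainty because the entering group is untested.

Compound 4 is estimated at 1500 nM in this assay, within 400 nM to 6000 nM, which is expected to correspond to a 6.3-fold higher number from compound 3 to compound 4 (0.80 log units; beyond the scatter).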

Compound 4, half-maximal effective concentration: 740 nM
For compound 4 the middle estimate is 2.0-fold (0.31 log units) above the measured one, within the range that was stated.
By their numbers in this assay, from the lowest: compound 3; then compound 4; then compound 1; then compound 2.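

In this assay, the change at the carbonyl carbon also raises the number when the 1-hydroxy-2,2-dimethylpropyl group is present: a 3.1-fold higher number from compound 3 to compound 4 (0.49 log units; beyond the scatter). This has the same direction as an 8.4-fold higher number from compound 1 to compound 2 (0.92 log units; beyond the scatter), so across the two pairs, both replacements of propargylamino by a methyl-bearing amino group go the same way, although the second group on the nitrogen and the rest of the molecule differ between the pairs. With a carboxylic acid on the amide side, compound 4 still gives 740 nM, but no evidence at hand explains the rise or connects it to any feature of the entering group.

The step changes both groups on the amide nitrogen at once, so the contributions of the added methyl and of the carboxymethyl group remain unseparated. A (carboxymethyl)amino amide without the methyl, a (methyl)(propargyl)amino amide, or a methyl ester in place of the carboxylic acid, each on the 1-hydroxy-2,2-dimethylpropyl background, would divide that step into its parts.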